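The source may report more compounds than this note shows. Statements on the series, on what has been measured and on what is new or still open speak of the compounds shown alone.

Within the data shown here, in a functional assay on HCT-116 cells (Homo sapiens) for antiproliferative activity (a lower number here means a stronger inhibitor, a higher number a weaker inhibitor), compound 2 `Cc1cc2c(F)c(Oc3ncnc(N)c3/C=N/O)ccc2[nH]1` gives 1140 nM, the lower of the two numbers so far, while compound 1 `Cc1cc2c(F)c(Oc3ncnc(N)c3/C=N/OCC3CCCCC3)ccc2[nH]1` gives 16100 nM. Next is compound 3 `CCO/N=C/c1c(N)ncnc1Oc1ccc2[nH]c(C)cc2c1F`, whose difference from compound 2 is ethyl in place of hydrogen on an oxygen, or hydroxy to ethoxy. Among the measured compounds shown here, one measured step bears on this change: a 14-fold lower number from compound 1 to compound 2 (1.15 log units; beyond the scatter), a large step beyond the scatter, with hydrogen in place of cyclohexylmethyl on an oxygen. Read in reverse, it points to a higher number when that hydrogen is replaced. Ethyl is a shorter group than cyclohexylmethyl, so a smaller step in that same direction is expected in this assay, although a single pair cannot show how the size of the step scales. The expected step is a 2.6-fold higher number from compound 2 to compound 3 (0.42 log units; beyond the scatter). For compound 3 the estimated value is 3000 nM, with an expected range of 1200 nM to 9000 nM.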

Compound 3, half-maximal inhibitory concentration: 36 nM
For compound 3 the middle estimate is 83-fold (1.92 log units) above the measured one; the whole stated range lies above it.
By their numbers in this assay, from the lowest: compound 3; then compound 2; then compound 1.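

In this assay, substitution on this oxygen does not simply raise the number: ethyl in place of hydrogen gives a 32-fold lower number from compound 2 to compound 3 (1.50 log units; beyond the scatter), the opposite direction to the cyclohexylmethyl of compound 1. Methyl in place of cyclohexyl on the saturated chain carbon bound to the oxygen gives a 450-fold lower number from compound 1 to compound 3 (2.65 log units; beyond the scatter), so the result here depends strongly on the group present, and the order of ethyl, then hydrogen, then cyclohexylmethyl does not run with chain length. No measurement in hand accounts for this reversal.

Going by these compounds, with only these three groups on the oxygen, it remains open where the lowest number lies among methyl, propyl or a longer chain. Also open, on these data alone, is how a chain ending in an amine or a carboxylic acid would compare with ethyl.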